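The source may hold more compounds than are shown below. What is called first, only, known or untested is meant among the compounds shown, and "the series" means these compounds.

Among the measured compounds shown here, compound 1 `CCCNc1nc(N)c(C(=O)N=C(N)N)nc1Cl` is one of two compounds so far examined in an assay for inhibition of acid-sensing ion channel 3 (Homo sapiens), read by patch clamp, tested at 20 uM; on this read-out lower numbers stand for less inhibition and higher numbers for more inhibition at the one concentration tested (going by the name of the read-out). In this assay compound 1 gives 91%, the lower of the two numbers available. Its nearest neighbour on this read-out is compound 2 `NC(N)=NC(=O)c1nc(Cl)c(NCc2ccc3ccccc3c2)nc1N`, which in this assay gives 93%; the two values lie within the usual scatter of repeated measurements, so nothing separates them. For the measured compounds named here, no pair of measured compounds differs in only one place, so the effect of a single alteration cannot be traced from what has been measured. Compound 3 `NC(N)=NC(=O)c1nc(Cl)c(NCC2CCCCC2)nc1N` has not yet been measured. It differs from compound 1 by cyclohexyl in place of ethyl on a saturated chain carbon bound to a nitrogen on an aromatic ring. Both measured values already sit near the top of the scale in this assay, so little room remains for an increase, and a drop is not anticipated because compound 2, built on the same core, gives 93%. The expected step is a number 1 percentage points higher from compound 1 to compound 3 (within the scatter), which is not beyond the scatter. For compound 3 the value in this assay is estimated at 92%, with a range from 80% to 99%.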

Compound 3, a percentage reported as inhibition, at one concentration (the size of the read-out at that concentration, not a potency): 96%
Beside the measured number, compound 3's estimate is 4 percentage points below it, within the range that was stated.
By their numbers in this assay, from the lowest: compounds 1, 2 and 3 (each within the scatter of the next).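

In this assay, putting cyclohexyl in place of ethyl on a saturated chain carbon bound to a nitrogen on an aromatic ring gives a number 5 percentage points higher from compound 1 to compound 3 (within the scatter). Among the compounds shown here, this is the first measured pair that differs in only one place, and it shows that this position accepts a six-membered non-aromatic ring of carbon only in place of a small open chain, with no difference that can be told from the scatter. Compound 1 gives 91% and compound 3 gives 96%, both close to the top of the percentage scale, and no further evidence bearing on this result is available.

On these data alone, whether the same place also accepts an amine, a carboxylic acid or a much longer chain such as octyl in place of cyclohexyl remains open. As far as these compounds go, a reading at one concentration is not a potency, so how compound 1 and compound 3 compare across a range of concentrations, where a real difference between them might or might not appear, also remains open.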